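The source may report more compounds than this note shows. Statements on the series, on what has been measured and on what is new or still open speak of the compounds shown alone.

Of the compounds shown here, two have been measured in an assay on C6 glioma cells for displacement of a labelled ligand from sodium- and chloride-dependent glycine transporter 1 (Rattus norvegicus), read by scintillation counting, with stated times of 30 min and 10 min; a higher number here means a weaker inhibitor, a lower number a stronger inhibitor. Compound 1 `CCc1nnc(N2CCC(c3ccccc3)CC2)n1-c1ccccc1F` gives 3700 nM. Compound 2 `CCc1nnc(-c2ccc(-c3ccccc3)cc2)n1-c1ccccc1C` gives 300 nM, the lowest of the two numbers, with compound 1 standing beyond the usual scatter from it. The next step goes from compound 2 to compound 3 `CCc1nnc(-c2ccc(-c3ccccc3)cc2)n1-c1cccc(CO)c1C`, which carries hydroxymethyl in place of hydrogen on an aromatic carbon. Within the data shown here, no measured pair shows what such a change does here, so the step expected from compound 2 to compound 3 in this assay is a 1.3-fold higher number from compound 2 to compound 3 (0.12 log units; within the scatter), none beyond the scatter in either direction. Compound 3 is therefore estimated at 400 nM, between 150 nM and 1200 nM.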

Compound 3, half-maximal inhibitory concentration: 250 nM
For compound 3 the middle estimate is 1.6-fold (0.20 log units) above the measured one; measured number inside the range.
By their numbers in this assay, from the lowest: compounds 3 and 2 (each within the scatter of the next); then compound 1.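

Adding hydroxymethyl to an aromatic carbon, ortho to a methyl group, gives a 1.2-fold lower number from compound 2 to compound 3 (0.08 log units; within the scatter) in this assay. This position therefore carries a group with a hydrogen-bond donor and acceptor while the number stays within the scatter of that of the parent compound. Nothing measured here offers a reason for this result. From the compounds shown here alone, what remains open is how an amine, a carboxylic acid or a longer chain would fare at this position. Also open, going by these compounds, is whether the oxygen of hydroxymethyl matters, which an ethyl group could help to show.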